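A few compounds are considered here, and "the series" means these few. Any claim that something is new, unique, unknown or untested is made for them only; others in the source may bear on it.

Compound 1 `CC1=CC(=O)OC(CSc2nc(-c3ccccc3)c(-c3ccccc3)[nH]2)C1` — in an assay on microsomes from liver for inhibition of sterol O-acyltransferase 1 (Rattus norvegicus) (on this read-out lower numbers stand for stronger inhibition and higher numbers for weaker inhibition), compound 1 gives 200 nM.
Compound 2 `O=C1CC(O)CC(CSc2nc(-c3ccccc3)c(-c3ccccc3)[nH]2)O1` — in this assay compound 2 gives 910 nM.
Compound 3 `CC1(C)CC(=O)OC(CSc2nc(-c3ccccc3)c(-c3ccccc3)[nH]2)C1` — in this assay compound 3 gives 100 nM.

On these numbers compound 3 stands lowest: a 2.0-fold lower number from compound 1 to compound 3 (0.30 log units; within the scatter), and a 9.1-fold lower number from compound 2 to compound 3 (0.96 log units; beyond the scatter). Compound 4 `O=C1CCC(CSc2nc(-c3ccccc3)c(-c3ccccc3)[nH]2)N1` differs from compound 3 in that (a group of 6 heavy atoms (4 carbon, 1 nitrogen, 1 oxygen; one five-membered non-aromatic ring with 1 hetero atom) in place of a group of 9 heavy atoms (7 carbon, 2 oxygen; one six-membered non-aromatic ring with 1 hetero atom), on a saturated chain carbon bound to a sulfur). Among the compounds with values here, no measured step makes exactly this exchange. Two bear on it: a 4.6-fold higher number from compound 1 to compound 2 (0.66 log units; beyond the scatter) and a 9.1-fold lower number from compound 2 to compound 3 (0.96 log units; beyond the scatter), both showing that the hydroxy lactone, with fewer carbons and an added donor, is the weakest variant of this ring. A smaller ring carrying an amide hydrogen is therefore expected to raise the number again. Compound 4 is estimated at 500 nM, within 150 nM to 1600 nM. The expected step is a 5.0-fold higher number from compound 3 to compound 4 (0.70 log units; beyond the scatter).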

Compound 4, half-maximal inhibitory concentration: 360 nM
Compound 4: the middle estimate sits 1.4-fold (0.14 log units) above what was measured; measured number inside the range.
By their numbers in this assay, from the lowest: compounds 3, 1 and 4 (each within the scatter of the next, the first and the last beyond it); then compound 2.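

The 5-oxopyrrolidin-2-yl group shows that a five-membered ring with a nitrogen can stand on the saturated chain carbon bound to a sulfur without leaving the range of the six-membered rings in this assay: a 1.8-fold higher number from compound 1 to compound 4 (0.26 log units; within the scatter) stays within the scatter, while a 3.6-fold higher number from compound 3 to compound 4 (0.56 log units; beyond the scatter) lies beyond it. The group also reads clear of the hydroxy-bearing ring, with a 2.5-fold lower number from compound 2 to compound 4 (0.40 log units; beyond the scatter), so the two groups carrying a hydrogen-bond donor do not share one level. No evidence on the origin of these differences is available.

The compounds shown leave open whether ring size or the ring nitrogen carries the step from compound 3; the two change together here. They also do not tell how a carboxylic acid or an amine would read at this place.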